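A Hexyl Chain in Place of a Hydroxyethyl Group

The source may hold more compounds than are shown below. What is called first, only, known or untested is meant among the compounds shown, and "the series" means these compounds.

Compound 1 `OCCNc1nccc2c1ncn2C1O[C@H](CO)[C@@H](O)[C@H]1O` gives 6% in a functional assay on EL4 cells (Mus musculus) for inhibition, tested at 100 uM; on this read-out lower numbers stand for less inhibition and higher numbers for more inhibition at the one concentration tested (going by the name of the read-out). For the measured compounds named here, this is the only number reported in this assay; the two remaining values are limits. Compound 2 `[N-]=[N+]=Nc1[nH]ccc2ncnc1-2` shows < 5%, a limit of the assay rather than a number. Compound 3 `OC[C@H]1O[C@@H](n2cnc3c(Cl)nccc32)C[C@@H]1O` likewise shows < 5%, also a limit. The two other values therefore sit at the limit of < 5% in this assay, at which 2 of the 3 values shown sit, and compound 1 stands just above it.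

Compound 4 `CCCCCCNc1nccc2c1ncn2C1O[C@H](CO)[C@@H](O)[C@H]1O` differs from compound 1 in one place: butyl in place of hydroxy on a saturated chain carbon, two bonds along the chain from a nitrogen on an aromatic ring. Going by the values given here, no measured pair shows what such a change does here. With all three known values low, the expected step from compound 1 to compound 4 is a number 2 percentage points higher from compound 1 to compound 4 (within the scatter), that is, nothing beyond the scatter. Compound 4 is therefore estimated at 8%, with a range from 0% to 22%.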

Compound 4, a percentage reported as inhibition, at one concentration (the size of the read-out at that concentration, not a potency): 14%
Estimate against measurement, compound 4: 6 percentage points below; measured number inside the range.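

In this assay, butyl in place of hydroxy gives a number 8 percentage points higher from compound 1 to compound 4 (within the scatter). This first measured step at this position therefore shows that going from 2-hydroxyethyl to hexyl changes the read-out by no more than the usual scatter, so this change gives no clear gain in inhibition. The read-out stays low across the compounds shown: the limit of < 5% in this assay, at which 2 of the 4 values shown sit.

As far as these compounds go, whether an amine or a carboxylic acid at the end of this chain would change the picture remains open. The same holds for a chain longer than hexyl.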